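Swapping the halogen-bearing ring for an oxygen-bearing one

The source may hold more compounds than are shown below. What is called first, only, known or untested is meant among the compounds shown, and "the series" means these compounds.

Of the compounds shown here, three that share one core have been measured in a functional assay on HT-29 cells (Homo sapiens) for cytotoxicity, read by MTT assay, with a stated time of 72 h; a higher number here means a weaker inhibitor, a lower number a stronger inhibitor. Compound 1 `CN(C)CCn1cnnc1-c1cc(Oc2ccc(NC(=O)N/N=C/c3ccc(Cl)cc3Cl)cc2F)ccn1` gives 390 nM. Compound 2 `COc1ccc(OC)c(/C=N/NC(=O)Nc2ccc(Oc3ccnc(-c4nncn4CCN(C)C)c3)c(F)c2)c1` gives 2070 nM, and compound 3 `CN(C)CCn1cnnc1-c1cc(Oc2ccc(NC(=O)N/N=C/c3ccc(F)cc3F)cc2F)ccn1` gives 960 nM. Compound 3 therefore stands second highest of the three numbers: its nearest neighbour is compound 2, since a 2.2-fold lower number from compound 2 to compound 3 (0.33 log units; beyond the scatter), and its furthest is compound 1, since a 2.5-fold higher number from compound 1 to compound 3 (0.39 log units; beyond the scatter).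

Compound 4 `COc1cc(/C=N/NC(=O)Nc2ccc(Oc3ccnc(-c4nncn4CCN(C)C)c3)c(F)c2)ccc1O` has not yet been measured in this assay. It differs from compound 3 in one place: 4-hydroxy-3-methoxyphenyl in place of 2,4-difluorophenyl on a carbon with a double bond to nitrogen. Going by the values given here, two measured steps bear on this exchange of a halogen-bearing ring for one carrying oxygen groups. In the first, a 5.3-fold higher number from compound 1 to compound 2 (0.72 log units; beyond the scatter). In the second, a 2.2-fold lower number from compound 2 to compound 3 (0.33 log units; beyond the scatter). Both times the ring with oxygen groups gave the higher number against the ring with halogens, so a modest rise is expected here as well: a 2.3-fold higher number from compound 3 to compound 4 (0.36 log units; beyond the scatter). Compound 4 is estimated to give 2200 nM, with a range from 900 nM to 6000 nM.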

Compound 4, half-maximal inhibitory concentration: 120 nM
Compound 4: middle estimate off by 18-fold (1.26 log units), on the high side; measured number below the stated range.
By their numbers in this assay, from the lowest: compound 4; then compound 1; then compound 3; then compound 2.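

In this assay the earlier pattern, in which a ring with oxygen groups gave a higher number than a ring with halogens, breaks at compound 4, whose 4-hydroxy-3-methoxyphenyl group outperforms both 2,4-difluorophenyl (an 8.0-fold lower number from compound 3 to compound 4 (0.90 log units; beyond the scatter)) and 2,4-dichlorophenyl (a 3.3-fold lower number from compound 1 to compound 4 (0.51 log units; beyond the scatter)). The mere presence of oxygen groups on this ring therefore does not set the outcome, since two rings carrying them lie far apart (a 17-fold lower number from compound 2 to compound 4 (1.24 log units; beyond the scatter)), and compound 2 is the only one that still fits the pattern. Nothing available explains this reversal.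

The compounds shown cannot separate the contribution of the hydroxy group from that of the arrangement of groups on the ring, as no ring here carries a hydroxy group alone. On these data alone, how an amine or a carboxylic acid on this ring would behave also remains open.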